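The source may hold more compounds than are shown below. What is called first, only, known or untested is meant among the compounds shown, and "the series" means these compounds.

Measured so far in a functional assay on CHO cells for agonist activity at G-protein coupled receptor 39 (Homo sapiens), read by calcium flux; a lower number here means a smaller maximal response, a higher number a larger maximal response:

Compound 1, `CNc1nc(NCc2ccccc2Cl)cc(-c2ccccn2)n1`, gives 86%.
Compound 2, `Cc1cc(NC(C)c2ccc(F)cc2)n2ncc(-c3ccccn3)c2n1`, gives 51%; 68% (2 entries).
Compound 3, `CNC(=O)C(Nc1cc(C)nc2c(-c3ccccn3)cnn12)c1ccc(F)cc1`, gives 75%.

Only two of these compounds give a single number in this assay, and compound 3 stands lower of the two. Compound 1 sits above compound 3 by a gap that lies beyond the usual scatter of repeated measurements. Compound 2 was measured twice, and its two entries, (the several entries of compound 2 in this assay, 51%; 68% (2 entries)), spread apart by more than the scatter, so compound 2 offers no single number to place it against compound 3.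

Compound 4, `Cc1cc(NCc2ccc(F)cc2)n2ncc(-c3ccccn3)c2n1`, has not yet been measured in this assay. It differs from compound 3 in one place: hydrogen in place of methylcarbamoyl on a saturated chain carbon bound to an aromatic carbon and a nitrogen on an aromatic ring. Apart from that change, compound 4 carries the same framework as compound 2, so the two entries of compound 2 are the best guide to what compound 4 might show.

Because the two entries of compound 2, (the several entries of compound 2 in this assay, 51%; 68% (2 entries)), both lie at or below the number of compound 3, the expected change is a number 10 percentage points lower from compound 3 to compound 4 (within the scatter), a lowering of the maximal response by only about the size of the scatter. Compound 4 is therefore estimated to reach 65%, within a range from 45% to 85%.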

Compound 4, largest response reached (Emax), in percent of the reference or control that the assay uses: 57%
Compound 4: the middle estimate sits 8 percentage points above what was measured; measured number inside the range.
By their numbers in this assay, from the lowest: compound 4; then compound 3; then compound 1.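

In this assay, the saturated chain carbon bound to an aromatic carbon and a nitrogen on an aromatic ring now has its first readable step: replacing methylcarbamoyl with hydrogen gives a number 18 percentage points lower from compound 3 to compound 4 (beyond the scatter). In this single pair, methylcarbamoyl therefore goes with the larger maximal response, yet the group is not needed for a response, since compound 4 still gives 57%. Compound 2 carries a methyl on that same carbon where compound 4 has hydrogen, and the value of compound 4 lies inside the wide spread of the entries for compound 2, so this pair gives no readable step: the several entries of compound 2 in this assay, 51%; 68% (2 entries)

From the compounds shown here alone, it remains open whether the higher response of compound 3 depends on the whole methylcarbamoyl group or on only part of it, and how an amine, a carboxylic acid or a longer chain would behave on this carbon. It is also unknown whether the same replacement would shift the maximal response in the same direction on a different core, such as that of compound 1.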